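From 3-chlorophenyl to 4-nitrophenyl on compound 2

The source may hold more compounds than are shown below. What is called first, only, known or untested is meant among the compounds shown, and "the series" means these compounds.

In a functional assay on HL-60 cells (Homo sapiens) for inhibition, read by CCK-8 assay, with a stated time of 48 h (a lower number here means a stronger inhibitor, a higher number a weaker inhibitor), compound 2 `O=S(=O)(NCCNC(=S)Nc1cccc(Cl)c1)c1ccc(-c2ccccc2OCc2ccccc2)s1` gives > 50000 nM, which is a limit of the assay and not a number. That places compound 2 at the limit of > 50000 nM in this assay, at which 1 of the 3 values shown sits. Compound 1 `O=S(=O)(NCCNC(=S)Nc1cccc(Cl)c1)c1ccc(-c2ccccc2OCc2cccc(O)c2)s1` carries a hydroxy group that compound 2 lacks. Compound 1 gives 1800 nM, and compound 3 `O=S(=O)(NCCNC(=S)Nc1cc(C(F)(F)F)cc(C(F)(F)F)c1)c1cc(-c2ccccc2Oc2ccc(O)c(O)c2)cs1` gives 600 nM.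

Compound 4 `O=[N+]([O-])c1ccc(NC(=S)NCCNS(=O)(=O)c2ccc(-c3ccccc3OCc3ccccc3)s2)cc1` differs from compound 2 in one place: 4-nitrophenyl in place of 3-chlorophenyl on an amide-type nitrogen, with 4-nitrophenyl in place of 3-chlorophenyl on an amide-type nitrogen. For the measured compounds named here, no measured step changes this group alone. Going by the values given here, the one measured step, an at least 27-fold higher number from compound 1 to compound 2 (1.44 log units; beyond the scatter), concerns the hydroxy group, so it bears on the change only indirectly, and compound 4 lacks that hydroxy group as well. In this assay, the expected result is therefore no step beyond the scatter, with weak inhibition retained and a fair chance of another limit. The estimated change is an at least 1.1-fold lower number from compound 2 to compound 4 (0.04 log units; that floor lies within the scatter). For compound 4 the expected value is 45000 nM, with an estimated range of 15000 nM to 100000 nM.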

Compound 4, half-maximal inhibitory concentration: > 50000 nM
Compound 4 was reported as a limit; the forecaster's own chance of this, stated with the estimate: 60%; middle value at least 1.1-fold (0.04 log units) away from the limit.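

In this assay compound 4 gives > 50000 nM which is a limit of the assay and not a number. For the compounds shown here, compound 2 also stands at a limit, so no step between compound 2 and compound 4 can be read. The compounds shown leave open whether 4-nitrophenyl in place of 3-chlorophenyl changes inhibition when the hydroxy group of compound 1 is present.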